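The compounds below may be only part of what the source reports. "The series", "measured", "known", "first", "only" and "open" are said of these compounds alone.

Compound 1 `CCCCCn1c(Cc2cc(OC)c(OC)c(OC)c2)nc2c(N)nc(F)nc21` carries a straight five-carbon chain on one ring nitrogen of its core and a fluoro group on the aromatic carbon between two ring nitrogen atoms. In a functional assay on MCF7 cells (Homo sapiens) for antiproliferative activity (a lower number here means a stronger inhibitor, a higher number a weaker inhibitor), compound 1 gives 36300 nM. Among the compounds with values here, its only measured neighbour is compound 2 `CC[C@H](C)Cn1c(Cc2cc(OC)c(OC)c(OC)c2)nc2c(N)nc(F)nc21`, which in this assay gives 43700 nM. The step of a 1.2-fold higher number from compound 1 to compound 2 (0.08 log units; within the scatter) shows that reshaping the chain into sec-butyl leaves the result essentially unchanged; the two numbers lie within the scatter of each other, so neither compound can be told apart from the other on this evidence.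

Compound 3 `CCCCCn1c(Cc2cc(OC)c(OC)c(OC)c2)nc2c(N)ncnc21` takes a different route from compound 1: hydrogen in place of fluoro on an aromatic carbon. Within the data shown here, no measured step touches this position; the one available step concerns the chain on the ring nitrogen, so it says nothing about removing the fluoro group. Without guidance, the expectation for compound 3 in this assay is a value near that of compound 1, with a wide range in both directions, and the estimated step of a 1.1-fold higher number from compound 1 to compound 3 (0.04 log units; within the scatter) is therefore no clear shift beyond the scatter. The estimate for compound 3 is 40000 nM, between 10000 nM and 160000 nM.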

Compound 3, half-maximal inhibitory concentration: 61700 nM
Compound 3: the middle estimate sits 1.5-fold (0.19 log units) below what was measured; the measured number falls inside the stated range.
By their numbers in this assay, from the lowest: compounds 1, 2 and 3 (each within the scatter of the next).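

In this assay, within the data shown here, the step of a 1.7-fold higher number from compound 1 to compound 3 (0.23 log units; within the scatter) is the first measured change at the aromatic carbon between two ring nitrogen atoms, and it puts hydrogen in place of fluoro without a result that can be told apart from the original. The earlier pair spoke only about the chain on the ring nitrogen, whereas this pair shows that, with that chain unchanged, the fluoro group is not needed to reach a number within the scatter of the fluorinated compound. Nothing shown offers a measured explanation for this outcome.

Fluoro and hydrogen are the only two groups shown on this carbon, so it remains open whether a larger change, such as a chloro group, an amine or a short alkyl chain, would shift the number beyond the scatter. On these data alone, it also remains open whether hydrogen in place of fluoro would give a similar result with the sec-butyl chain of compound 2, or whether the two positions influence each other.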